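The source may report more compounds than this note shows. Statements on the series, on what has been measured and on what is new or still open speak of the compounds shown alone.

Measured in an ADME assay on A549 cells (Homo sapiens) for cytotoxicity; on this read-out higher numbers stand for weaker inhibition and lower numbers for stronger inhibition:

Compound 1 `O=C(/C=C/c1ccc2ccc(C(F)(F)F)cc2n1)c1ccncc1` gives 15000 nM
Compound 2 `O=C(/C=C/c1ccc2c(C(F)(F)F)cccc2n1)c1ccccn1` gives 43100 nM

Of these two numbers, the higher belongs to compound 2 at 43100 nM, which here means the weaker inhibition. Compound 1 has the lower number. That gap is beyond the usual scatter of repeat measurements.

Compound 3 `O=C(/C=C/c1ccc2c(C(F)(F)F)cccc2n1)c1ccncc1` has not been measured yet. It keeps the core of compound 2 and changes one group, with pyridin-4-yl in place of pyridin-2-yl on a carbonyl carbon. The two compounds have the same atoms, joined differently.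

No single change has been measured in this small set, so any forecast is rough. The best guide is compound 1 at 15000 nM, which also carries pyridin-4-yl but differs from compound 3 elsewhere too. A modest move toward a lower number therefore seems likely. The estimated change, a 1.7-fold lower number from compound 2 to compound 3 (0.24 log units; within the scatter), is expected to be small and may not clear the scatter. For compound 3 the expected value is 25000 nM, within an estimated range of 10000 nM to 60000 nM.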

Compound 3, half-maximal inhibitory concentration: 45400 nM
For compound 3 the middle estimate is 1.8-fold (0.26 log units) below the measured one; the measured number falls inside the stated range.
By their numbers in this assay, from the lowest: compound 1; then compounds 2 and 3 (each within the scatter of the next).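

In this assay the exchange of pyridin-2-yl for pyridin-4-yl on a carbonyl carbon gives a 1.1-fold higher number from compound 2 to compound 3 (0.02 log units; within the scatter) and so, on this core, the read-out does not tell the two rings apart. Compound 1 gives 15000 nM with pyridin-4-yl on its carbonyl carbon, while compound 3 gives 45400 nM with that same ring, so the ring alone does not account for the lower number of compound 1. Nothing available here explains why this exchange leaves the number where it was.

Still open, on these data alone, is whether a phenyl ring or a pyridin-3-yl ring on the same carbonyl carbon would also leave the number in place on this core. As far as these compounds go, it is equally open whether pyridin-2-yl and pyridin-4-yl would read alike on the core of compound 1, where the trifluoromethyl group sits differently, since a matching pair on that core would show whether this result holds beyond a single core.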